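Compound 3: methoxy in place of methyl

The compounds below may be only part of what the source reports. "The series", "measured", "known", "first", "only" and "open" are said of these compounds alone.

Among the compounds with values here, in an ADME assay on L02 cells (Homo sapiens) for inhibition, read by CCK-8 assay, with a stated time of 48 h (on this read-out higher numbers stand for weaker inhibition of growth and lower numbers for stronger inhibition of growth), compound 1 (`Cc1ccc(Nc2nc(Nc3ccc(N4CCN(C)CC4)cn3)ncc2Cl)cc1`) gives 13900 nM as its reading, and compound 2 (`Cc1cccc(Nc2nc(Nc3ccc(N4CCN(C)CC4)cn3)ncc2Cl)c1`) gives 6080 nM as the lower of the two numbers so far. Within the data shown here, the one measured step is a 2.3-fold lower number from compound 1 to compound 2 (0.36 log units; beyond the scatter) and it is modest, with 3-methylphenyl in place of 4-methylphenyl.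

Next comes compound 3 (`COc1cccc(Nc2nc(Nc3ccc(N4CCN(C)CC4)cn3)ncc2Cl)c1`), which has methoxy in place of methyl on an aromatic carbon, meta to a large group. The counted difference is methoxy in place of methyl on an aromatic carbon and the rest of the structure stays the same.

Among the measured compounds shown here, no measured step exchanges methyl for methoxy, so the evidence is indirect. For the measured compounds named here, the only guide to scale in this assay is the modest step of a 2.3-fold lower number from compound 1 to compound 2 (0.36 log units; beyond the scatter) and that step concerns a shift of the methyl group, not a new group. No step beyond the scatter is therefore expected, and no direction is favoured. The expected change is a 1.2-fold higher number from compound 2 to compound 3 (0.06 log units; within the scatter) and this estimate remains within the scatter. For compound 3 the estimated value is 7000 nM with an expected range from 2800 nM to 14000 nM in this assay.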

Compound 3, concentration for 50% growth inhibition: 3470 nM
Beside the measured number, compound 3's estimate is 2.0-fold (0.30 log units) above it, within the range that was stated.
By their numbers in this assay, from the lowest: compounds 3 and 2 (each within the scatter of the next); then compound 1.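

Notes on the aromatic carbon carrying the 3-substituent, read in this assay: methoxy in place of methyl leaves compound 3 not separable from compound 2 (a 1.8-fold lower number from compound 2 to compound 3 (0.24 log units; within the scatter)), so this position accepts the additional oxygen with no change that can be read. Against the 4-methylphenyl of compound 1, both groups now measured at this position give steps beyond the scatter (a 2.3-fold lower number from compound 1 to compound 2 (0.36 log units; beyond the scatter) and a 4.0-fold lower number from compound 1 to compound 3 (0.60 log units; beyond the scatter)), which extends the earlier single contrast to a second group, though compound 1 remains the only reference for it and the step to 3-methoxyphenyl alters both the group and its place. No measured evidence at hand accounts for any of these numbers.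

Still open, going by these compounds, is how methoxy reads on the ring carbon that holds methyl in compound 1, which would separate the effect of the group from that of its place. Equally open, on these data alone, is whether this position stays as undiscriminating with an amine, a carboxylic acid or a longer chain such as butoxy, since methyl and methoxy alone span only a narrow set of groups.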